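This account rests on a few compounds, and the source may have more. Where it says the series, first, only, none or still open, it means among the compounds named here.

Measured in a functional assay on A549 cells (Homo sapiens) for inhibition, read by MTT assay, with a stated time of 48 h; a higher number here means a weaker inhibitor, a lower number a stronger inhibitor:
- compound 1 `Cc1ccc(NC(=O)Nc2cccc(-c3cccc4[nH]nc(N)c34)c2)cc1Cl`: 1750 nM
- compound 2 `Nc1n[nH]c2cccc(-c3cccc(NC(=O)Nc4cccc(F)c4)c3)c12`: 1360 nM
- compound 3 `Nc1n[nH]c2cccc(-c3cccc(NC(=O)Nc4ccc(F)c(F)c4)c3)c12`: 3040 nM

Compound 3 is at 3040 nM, which puts it close to one neighbour but not the other: a 1.7-fold higher number from compound 1 to compound 3 (0.24 log units; within the scatter), and a 2.2-fold higher number from compound 2 to compound 3 (0.35 log units; beyond the scatter).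

Compound 4 `Nc1n[nH]c2cccc(-c3cccc(NC(=O)Nc4ccc(Cl)cc4Cl)c3)c12` has 2,4-dichlorophenyl in place of 3,4-difluorophenyl on an amide-type nitrogen. Among the compounds with values here, no measured compound carries the 2,4-dichlorophenyl group, so only the other changes at this nitrogen bear on the step. Besides the two above, there is a 1.3-fold lower number from compound 1 to compound 2 (0.11 log units; within the scatter). All three steps are small, and only the modest step to compound 3 clears the scatter.

A step of similar size is therefore expected in this assay, with no clear direction, and none beyond the scatter. A slight drift back towards the other two values is assumed, giving an expected 1.4-fold lower number from compound 3 to compound 4 (0.14 log units; within the scatter). For compound 4 the estimated value is 2200 nM, with an expected range of 900 nM to 5500 nM.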

Compound 4, half-maximal inhibitory concentration: > 500000 nM
Compound 4: only a limit was reported (the forecaster's own chance of this, stated with the estimate: 5%); middle value at least 220-fold (2.35 log units) away from the limit.
By their numbers in this assay, from the lowest: compounds 2, 1 and 3 (each within the scatter of the next, the first and the last beyond it). At a limit, above all of these: compound 4.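

In this assay compound 4 gives > 500000 nM, which is a limit of the assay and not a number. Within the data shown here, its steps are an at least 160-fold higher number from compound 3 to compound 4 (2.21 log units; beyond the scatter), an at least 360-fold higher number from compound 2 to compound 4 (2.56 log units; beyond the scatter) and an at least 280-fold higher number from compound 1 to compound 4 (2.45 log units; beyond the scatter), all large and far greater than any step among the earlier compounds. The aryl group on this amide-type nitrogen is therefore not freely interchangeable: the earlier changes there left the values close together, whereas 2,4-dichlorophenyl in place of 3,4-difluorophenyl takes the series to the limit of the read-out.

This single change alters both the halogen and the substitution pattern, and the compounds shown do not separate the two. An aryl group bearing a single chloro substituent, or a methoxy group in place of the halogens, would help show which part of the change matters.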